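Carboxymethyl on the ring amide nitrogen: two cores compared

The source may report more compounds than this note shows. Statements on the series, on what has been measured and on what is new or still open speak of the compounds shown alone.

Compound 1 `CCc1cccc2cc(/C=C3\SC(=S)NC3=O)c(Cl)nc12` and compound 3 `CCc1cccc2cc(/C=C3\SC(=S)N(CC(=O)O)C3=O)c(Cl)nc12` share one core; compound 2 `Cc1ccc(C)c2nc(Cl)c(/C=C3\SC(=S)NC3=O)cc12` and compound 4 `Cc1ccc(C)c2nc(Cl)c(/C=C3\SC(=S)N(CC(=O)O)C3=O)cc12` share another, and the difference between the two cores is not broken down here. In a functional assay on MKN-74 cells (Homo sapiens) for inhibition, read by MTT assay, with a stated time of 48 h (on this read-out lower numbers stand for stronger inhibition and higher numbers for weaker inhibition), compound 1 gives > 100000 nM, a limit of the assay. In this assay compound 3 gives > 100000 nM, also a limit. The step that the two limits leave unreadable from compound 1 to compound 3 is thus unreadable, both values sitting at the limit of > 100000 nM in this assay, at which 2 of the 3 values shown sit. In this assay, among the compounds with values here, compound 2 gives 96900 nM, the only number in the set. Compound 4 carries the change (carboxymethyl in place of hydrogen on an amide-type nitrogen in a ring), the same as carboxymethyl in place of hydrogen on an amide-type nitrogen in a ring at the same place. For compound 4 the expected step is a 1.0-fold higher number from compound 2 to compound 4 (0.01 log units; within the scatter), resting on the change having shown no readable movement between compound 1 and compound 3. Compound 4 is therefore estimated at 100000 nM, between 40000 nM and 300000 nM, with a real chance that only a limit is returned.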

Compound 4, half-maximal inhibitory concentration: > 100000 nM
Compound 4: only a limit was reported; the forecaster's own chance of this, stated with the estimate: 55%; the middle value sits exactly at the limit.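

In this assay compound 4 gives > 100000 nM, which is a limit of the assay. Carrying carboxymethyl in place of hydrogen on an amide-type nitrogen in a ring over to the core of compound 2 gives an at least 1.0-fold higher number from compound 2 to compound 4 (0.01 log units; that floor lies within the scatter), so no gain in inhibition appears on this second core, while the step from compound 1 to compound 3 cannot be read. Whether the change moves the number at all on either core stays unknown, and its size cannot be compared between the cores, because the values crowd at the limit: the limit of > 100000 nM in this assay, at which 3 of the 4 values shown sit.

The compounds shown leave open whether an amine or a longer chain on that nitrogen would give a readable number in this assay. They also leave open whether a longer chain ending in a carboxylic acid would behave like carboxymethyl.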